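A few compounds are considered here, and "the series" means these few. Any claim that something is new, unique, unknown or untested is made for them only; others in the source may bear on it.

Measured so far:
- compound 1, `CCc1nc2c(-c3ccc(Cl)cc3Cl)ccnc2n1[C@@H](CC)C1CC1`, in an assay for binding affinity to Corticotropin releasing factor receptor (Rattus norvegicus) (on this read-out higher numbers stand for weaker inhibition and lower numbers for stronger inhibition), gives 0.4 nM
- compound 2, `CCc1nc2c(-c3ccc(Cl)cc3Cl)ccnc2n1[C@H](CC)C1CC1`, in this assay gives 0.2 nM
- compound 3, `CCc1nc2c(-c3ccc(Cl)cc3Cl)ccnc2n1C(C)C1CCC1`, in this assay gives 1 nM

Compound 3 stands at the highest of the three numbers; compound 1 lies nearest to it and compound 2 furthest. The two lower numbers belong to compounds that carry the 1-cyclopropylpropyl group and differ only in configuration as drawn, a step of a 2.0-fold lower number from compound 1 to compound 2 (0.30 log units; within the scatter), which stays within the scatter because of the fact that compounds 1 and 2 differ only in the configuration as drawn.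

Compound 4, `CCc1nc2c(-c3ccc(Cl)cc3Cl)ccnc2n1[C@H](C)C1CC1`, is built from compound 3 by the change (1-cyclopropylethyl in place of 1-cyclobutylethyl on an aromatic nitrogen). Among the compounds with values here, two measured steps bear on it: the moves from the 1-cyclopropylpropyl compounds to the 1-cyclobutylethyl compound, a 2.5-fold higher number from compound 1 to compound 3 (0.40 log units; beyond the scatter) and a 5.0-fold higher number from compound 2 to compound 3 (0.70 log units; beyond the scatter), both modest and both pointing toward weaker binding for the four-membered ring. Within the data shown here, compound 4 keeps the three-membered ring of compounds 1 and 2 but shortens the chain to 1-cyclopropylethyl, which no measured pair tests directly. A step back toward the lower numbers, a 1.7-fold lower number from compound 3 to compound 4 (0.22 log units; within the scatter), is therefore expected, though not necessarily the full distance. Compound 4 is estimated at 0.6 nM, within 0.2 nM to 2 nM.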

Compound 4, inhibition constant: 0.6 nM
The estimate for compound 4 equals the measured number at the digits printed; low and high end bracket the measured number.
By their numbers in this assay, from the lowest: compounds 2, 1, 4 and 3 (each within the scatter of the next, the first and the last beyond it).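

Within the data shown here, compound 4 gives the first direct comparison of the two ring sizes on the 1-substituted ethyl group, and in this assay the exchange gives a 1.7-fold lower number from compound 3 to compound 4 (0.22 log units; within the scatter), so the ring swap alone cannot be told apart from repeat measurement. Shortening the chain with the three-membered ring kept gives a split reading: a 1.5-fold higher number from compound 1 to compound 4 (0.18 log units; within the scatter), but a 3.0-fold higher number from compound 2 to compound 4 (0.48 log units; beyond the scatter), so only the comparison with compound 2 shows a loss from the shorter chain, and a modest one. Nothing available explains these steps.

On these data alone, it remains open how the mirror-image form of compound 4 would compare with compound 4. Also open, as far as these compounds go, is how a cyclopentyl ring or a chain ending in a methoxy group would read on the same aromatic nitrogen.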